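The source may hold more compounds than are shown below. What is called first, only, known or untested is meant among the compounds shown, and "the series" means these compounds.

Of the compounds shown here, three have been measured in a functional assay on NIH3T3 cells (Mus musculus) (a higher number here means that more compound is needed for the effect, a lower number that less compound is needed), and a fourth awaits measurement. Compound 1 `Cn1cncc1C(OCc1nc(N2CCC(O)CC2)c(C#N)cc1-c1cccc(Cl)c1)c1ccc(C#N)cc1` gives 3.6 nM in this assay. Compound 2 `Cn1cncc1C(OCc1ccc(C#N)nc1-c1ccccc1)c1ccc(C#N)cc1` gives 19 nM. Compound 3 `Cn1cncc1C(OCc1ccc(C#N)cc1)c1ccc(C#N)c(-c2cccc3ccccc23)c1` gives 110 nM. Compound 2 thus stands second highest of the three numbers: compound 1 sits at a lower number and compound 3 at a higher one, and in each case the gap between compound 2 and its neighbour lies beyond the usual scatter of repeated measurements.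

The unmeasured compound 4 `Cn1cncc1C(OCc1ccc(C#N)nc1-c1cc(Cl)cc(Cl)c1)c1ccc(C#N)cc1` is obtained from compound 2 by a single change (3,5-dichlorophenyl in place of phenyl on an aromatic carbon). Going by the values given here, no pair of measured compounds shows the effect of this change on its own, so there is no directly comparable step to lean on. Compound 1, which carries a chloro-substituted phenyl on a different core, reaches 3.6 nM, but the core differs in several places, so its number cannot be read as a guide for compound 4.

Among the compounds with values here, with no step to anchor it, the expected change from compound 2 to compound 4 is a small one, a 1.6-fold lower number from compound 2 to compound 4 (0.20 log units; within the scatter), perhaps not beyond the scatter. Compound 4 is estimated at 12 nM in this assay, within a range from 4 nM to 40 nM.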

Compound 4, half-maximal effective concentration: 6 nM
The estimate for compound 4 lay 2.0-fold (0.30 log units) above the measured number; low and high end bracket the measured number.
By their numbers in this assay, from the lowest: compounds 1 and 4 (each within the scatter of the next); then compound 2; then compound 3.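

In this assay, going by these compounds alone, 3,5-dichlorophenyl in place of phenyl, on the aromatic carbon next to the ring nitrogen, gives a 3.2-fold lower number from compound 2 to compound 4 (0.50 log units; beyond the scatter), and this is the first step here in which a single change can be read on its own. Within the data shown here, it shows that this position accepts a larger aryl group carrying two chlorine atoms without any loss, and that the number moves modestly but beyond the usual scatter, something that the earlier compounds, which differ from one another in several places, could not show. Nothing measured on these compounds explains why the number falls.

Among these compounds, with only this one pair, it remains open whether a single chlorine would produce the same step, and whether both chlorine atoms are needed, or whether a methoxy group, an amine or a carboxylic acid on this phenyl ring would shift the number in the same direction or the opposite one. Also open, from the compounds shown here alone, is whether the step would carry over to a different core, such as the core of compound 1.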